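From 3-iodophenyl to 4-chlorophenyl on a shared core

A few compounds are considered here, and "the series" means these few. Any claim that something is new, unique, unknown or untested is made for them only; others in the source may bear on it.

Compound 1 `C#CCN(Cc1ccc2nc(C)nc(O)c2c1)c1cccc(CC)c1`: 5000 nM
Compound 2 `C#CCN(Cc1ccc2nc(C)nc(O)c2c1)c1cccc(I)c1`: > 5300 nM (a limit)

In a functional assay on L1210 cells (Mus musculus) for inhibition (a lower number here means a stronger inhibitor, a higher number a weaker inhibitor), compound 2 gives > 5300 nM, which is a limit and not a number. Compound 3 `C#CCN(Cc1ccc2nc(C)nc(O)c2c1)c1ccc(Cl)cc1`, not yet measured, differs from it by 4-chlorophenyl in place of 3-iodophenyl on an amine nitrogen. For the measured compounds named here, the only measured step that bears on this change is an at least 1.0-fold higher number from compound 1 to compound 2 (0.02 log units; that floor lies within the scatter), with iodo in place of ethyl on an aromatic carbon. On that basis, the expected change in this assay is a step that the limit leaves unreadable from compound 2 to compound 3, and none beyond the scatter is expected. Compound 3 is estimated at 6000 nM, within an expected range of 2000 nM to 18000 nM.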

Compound 3, half-maximal inhibitory concentration: > 4000 nM
Compound 3 gave a limit, no number (the forecaster's own chance of this, stated with the estimate: 45%); the middle value is on the limit's open side.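

In this assay compound 3 gives > 4000 nM, a limit and not a number, so its steps from compound 1 and compound 2 cannot be read. The compounds shown leave open how 4-chlorophenyl compares with 3-iodophenyl or 3-ethylphenyl on the shared core.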